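The compounds below may be only part of what the source reports. "The series", "measured", "known", "first", "only" and "open" are said of these compounds alone.

Three close relatives share one core and differ only in the group carried on one ring nitrogen. Compound 1 `CNc1nc(N)nc2c1ncn2/C=C1/CC1(CO)CO` is the smallest, compound 2 `CC(C)Nc1nc(N)nc2c1ncn2/C=C1/CC1(CO)CO` bears an isopropyl there, and compound 3 `Nc1nc(NC2CCCC2)c2ncn(/C=C3/CC3(CO)CO)c2n1` a cyclopentyl. In an ADME assay on MOLT-3 cells (Homo sapiens) for cytotoxicity, with a stated time of 7 days (a higher number here means that more compound is tolerated, a lower number that less compound is tolerated), compound 1 gives > 20000 nM, which is a limit of the assay rather than a measured number. For compound 2 this assay records "not determined" (no result reported), so compound 2 stands without any number of its own on this scale. The change from compound 2 to compound 3 is cyclopentyl in place of isopropyl on a nitrogen on an aromatic ring. No measured step between any two of these compounds exists, so the size of the shift to expect in this assay cannot be read from a measured pair; the only anchor is that compound 1 sits at the limit of > 20000 nM in this assay, at which 1 of the 2 values shown sits, and a step no larger than the usual scatter seems most likely. Compound 3 is therefore expected to give 20000 nM in this assay, within an estimated range from 10000 nM to 40000 nM, quite possibly again only as a limit.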

Compound 3, half-maximal cytotoxic concentration: > 20000 nM
Compound 3 ended at the assay's limit; the forecaster's own chance of this, stated with the estimate: 80%; the middle value lies on the limit itself.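

Compound 1 and compound 3 both end as limits of the assay rather than as numbers, so no step between them can be read: the limit of > 20000 nM in this assay, at which 2 of the 3 values shown sit.

From the compounds shown here alone, whether compound 1 and compound 3 differ at all in this assay, and where compound 2 stands there, remains open.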